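Swapping a bromophenyl for pyrrole on the shared core

The source may hold more compounds than are shown below. What is called first, only, known or untested is meant among the compounds shown, and "the series" means these compounds.

Three measured compounds share one core and differ only in substituents on their outer aromatic rings. Compound 1 `O=C(/C(=C\c1ccc(Br)cc1)SCc1ccc(Cl)cc1)c1ccc(Br)cc1` gives 1000 nM in a functional assay on DU-145 cells (Homo sapiens) for inhibition, read by trypan blue exclusion, with a stated time of 96 h; a higher number here means a weaker inhibitor of growth, a lower number a stronger inhibitor of growth. Compound 2 `O=C(/C(=C\c1ccc(Br)cc1)SCc1ccc(Cl)cc1)c1ccc(Cl)cc1` gives 1000 nM in this assay, and compound 3 `Cc1ccc(CS/C(=C/c2ccc(Br)cc2)C(=O)c2ccc(Cl)cc2)cc1` gives 10000 nM. On these numbers compound 2 stands level with compound 1, the two together holding the lowest number of the three; the step of no change at the digits printed from compound 1 to compound 2 (within the scatter) lies within the scatter, while the step of a 10-fold higher number from compound 2 to compound 3 (1.00 log units; beyond the scatter) lies beyond it.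

Compound 4 `O=C(/C(=C\c1ccc[nH]1)SCc1ccc(Cl)cc1)c1ccc(Cl)cc1` differs from compound 2 in one place: 1H-pyrrol-2-yl in place of 4-bromophenyl on a double-bonded chain carbon bound to a double-bonded chain carbon. Neither measured step touches this part of the core; both alter a substituent on one of the other two aromatic rings, so no direct guide exists. The step of a 10-fold higher number from compound 2 to compound 3 (1.00 log units; beyond the scatter) shows that a single-group change on an aromatic ring can shift the number by a modest amount, and a shift of comparable size, in either direction, seems the reasonable expectation. Compound 4 is therefore estimated to give 2500 nM, within a range of 400 nM to 15000 nM. The expected step is a 2.5-fold higher number from compound 2 to compound 4 (0.40 log units; beyond the scatter).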

Compound 4, concentration for 50% growth inhibition: 10000 nM
Compound 4: the middle estimate sits 4.0-fold (0.60 log units) below what was measured; the measured number falls inside the stated range.
By their numbers in this assay, from the lowest: compounds 1 and 2 (each within the scatter of the next); then compounds 3 and 4 (each within the scatter of the next).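

Placing 1H-pyrrol-2-yl in place of 4-bromophenyl on a double-bonded chain carbon bound to a double-bonded chain carbon gives a 10-fold higher number from compound 2 to compound 4 (1.00 log units; beyond the scatter) in this assay. Within the data shown here, the earlier steps changed only substituents on the other two aromatic rings, so this is the first sign that the number also responds to a change at this position, and that this aromatic ring cannot be swapped for the pyrrole without a step beyond the scatter. The swap changes several things at once, as a six-membered carbon ring carrying bromine gives way to a five-membered ring with 1 hetero atom and 1 hydrogen-bond donor, and no measurement here explains the step.

The compounds shown leave open whether the bromine, the ring size or the ring nitrogen with its hydrogen governs this step. Plain phenyl and furan-2-yl at this position would help separate these parts of the change.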